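The source may hold more compounds than are shown below. What is called first, only, known or untested is meant among the compounds shown, and "the series" means these compounds.

Compound 1 `O=c1cc(-c2ccccc2)oc2cc(OCCCCNc3nc4ccc(Br)cc4s3)cc(O)c12` gives 6.57 ug/mL in a physicochemical assay, read by spectrophotometry, with a stated time of 10 min; on this read-out higher numbers stand for weaker inhibition and lower numbers for stronger inhibition.
Compound 2 `O=c1cc(-c2ccccc2)oc2cc(OCCCCNc3nc4ccc(F)cc4s3)cc(O)c12` gives 5.25 ug/mL in this assay.

Among the measured compounds shown here, compound 2 stands at the lower of the two numbers measured so far, but the step of a 1.3-fold lower number from compound 1 to compound 2 (0.10 log units; within the scatter) lies within the scatter, so the two values cannot be told apart. Compound 3 `O=c1cc(-c2ccccc2)oc2cc(OCCCCNc3nc4c(F)cc(F)cc4s3)cc(O)c12` differs from compound 2 by fluoro in place of hydrogen on an aromatic carbon. For the measured compounds named here, the only measured step that bears on this change is a 1.3-fold lower number from compound 1 to compound 2 (0.10 log units; within the scatter), where exchanging bromo for fluoro on the same ring system left the number within the scatter. Going by the values given here, no measured pair shows what a second fluoro group on this ring system does, so the expectation rests on the one step alone. On that basis no step beyond the scatter is expected in this assay. Compound 3 is therefore expected to come out around 5.5 ug/mL, with a range from 3 ug/mL to 10 ug/mL. The expected step of a 1.0-fold higher number from compound 2 to compound 3 (0.02 log units; within the scatter) is one that stays within the scatter.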

Compound 3, half-maximal inhibitory concentration: 5.76 ug/mL
Beside the measured number, compound 3's estimate is 1.0-fold (0.02 log units) below it; the range from low to high includes it.
By their numbers in this assay, from the lowest: compounds 2, 3 and 1 (each within the scatter of the next).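

Compound 3 puts a fluoro on an aromatic carbon ortho to a fused ring, turning 6-fluoro-1,3-benzothiazol-2-yl into 4,6-difluoro-1,3-benzothiazol-2-yl, and in this assay this gives a 1.1-fold higher number from compound 2 to compound 3 (0.04 log units; within the scatter). Among the compounds shown here, the earlier compounds varied only one halogen, so this is the first measured sign that a second fluoro on this ring leaves the read-out within the scatter, and the step of a 1.1-fold lower number from compound 1 to compound 3 (0.06 log units; within the scatter) shows the same when 4,6-difluoro-1,3-benzothiazol-2-yl stands in place of 6-bromo-1,3-benzothiazol-2-yl. No separate evidence bears on this result.

The compounds shown leave open whether a group other than a halogen at this position, such as an amine or a carboxylic acid, would give a step beyond the scatter. They also leave open whether a longer chain would do so.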